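Swapping Pyrrolidine for Morpholine on a Thiosemicarbazide

The source may report more compounds than this note shows. Statements on the series, on what has been measured and on what is new or still open speak of the compounds shown alone.

Compound 1 `Cc1ccnc(/C(N)=N/NC(=S)N2CCCC2)c1` is the reference point here. In a functional assay on MCF7 cells (Homo sapiens) for cytotoxicity, read by MTT assay, with a stated time of 72 h, tested at 30 uM (a lower number here means less inhibition of growth, a higher number more inhibition of growth at the concentration tested), compound 1 gives 82.2%. Compound 3 `N/C(=N\NC(=S)N1CCCCCC1)c1ccccn1` gives 76.5%, a number within the usual scatter of that of compound 1, so the two cannot be told apart. Compound 2 `N/C(=N\NC(=S)N1CCOCC1)c1ccc(F)cn1` gives 56.7%, which lies beyond the scatter below compound 1. Compound 4 `Cc1ccnc(/C(N)=N/NC(=S)N2CCOCC2)c1` has not yet been measured. It differs from compound 1 in one place: morpholin-4-yl in place of pyrrolidin-1-yl on a thiocarbonyl carbon. Going by the values given here, no pair of measured compounds differs only in this way, so the effect cannot be read off directly; the morpholin-4-yl group appears only in compound 2, which also carries a different core and gives 56.7%. A moderate drop is expected, a number 16.2 percentage points lower from compound 1 to compound 4 (beyond the scatter). Compound 4 is estimated at 66%, between 46% and 84%.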

Compound 4, percent growth inhibition at one concentration: 8.16%
Estimate against measurement, compound 4: 57.8 percentage points above, and the stated range ends above it.
By their numbers in this assay, from the lowest: compound 4; then compound 2; then compounds 3 and 1 (each within the scatter of the next).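

On the thiocarbonyl carbon of this core, the choice of ring matters greatly: in this assay, morpholin-4-yl in place of pyrrolidin-1-yl gives a number 74 percentage points lower from compound 1 to compound 4 (beyond the scatter). Going by these compounds alone, this pair is the first to show the effect of this change on its own, as the morpholin-4-yl group had previously appeared only on a different core. Nothing measured here explains the step.

The change swaps a five-membered ring for a six-membered one and also adds a ring oxygen, and the pair cannot show which of these matters. A piperidin-1-yl group, a six-membered ring without oxygen, on the same core would separate the two.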